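The compounds below may be only part of what the source reports. "The series", "measured", "known", "first", "only" and "open" are said of these compounds alone.

Compound 1, `COc1ccc(C2N=C(SCc3ccccc3Cl)NC(C)=C2C(=O)Nc2ccc(F)cc2)cc1OC`: 21%
Compound 2, `CC1=C(C(=O)Nc2ccc(Br)cc2)C(c2ccc(Cl)cc2Cl)N=C(SCc2ccccc2)N1`: 8.2%
Compound 3, `CC1=C(C(=O)Nc2ccc(Br)cc2)C(c2ccc(Cl)cc2Cl)N=C(SCc2ccccc2Cl)N1`: 16.4%

In a functional assay on the whole organism (artery, strain albino) with Rattus norvegicus as the target, with a stated time of 900 min, at a dose of 10 mg/kg by the oral route (a higher number here means more inhibition at the dose given (going by the name of the read-out), a lower number less inhibition), compound 3 stands second highest of the three numbers, with compound 1 nearest to it and compound 2 furthest, both gaps lying within the scatter. Compound 4, `CC1=C(C(=O)Nc2ccc(Br)cc2)C(c2ccc(Cl)cc2Cl)N=C(SCc2ccc(Cl)cc2)N1`, differs from compound 3 by 4-chlorophenyl in place of 2-chlorophenyl on a saturated chain carbon bound to a sulfur. For the measured compounds named here, the one measured step, a number 8.2 percentage points higher from compound 2 to compound 3 (within the scatter), concerns adding chlorine to this benzyl group rather than moving it, and it stayed within the scatter, so it bears on the present change only loosely. Nothing measured shows the effect of shifting the chlorine itself. The step from compound 3 to compound 4 is therefore expected to be a number 1.4 percentage points lower from compound 3 to compound 4 (within the scatter), none beyond the scatter. Compound 4 is estimated at 15%, between 4% and 28%.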

Compound 4, a percentage reported as inhibition, in the whole organism at one dose (the size of the read-out at that dose, not a potency): 22.1%
Compound 4: middle estimate off by 7.1 percentage points, on the low side, and the stated range covers the measured number.
By their numbers in this assay, from the lowest: compounds 2, 3, 1 and 4 (each within the scatter of the next, the first and the last beyond it).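

In this assay, the change from 2-chlorophenyl to 4-chlorophenyl on the saturated chain carbon bound to a sulfur gives a number 5.7 percentage points higher from compound 3 to compound 4 (within the scatter), so the two placements of the chlorine cannot be told apart. Even so, only the 4-chlorobenzyl group separates from the plain benzyl group, with a number 13.9 percentage points higher from compound 2 to compound 4 (beyond the scatter), the only step shown that passes the scatter, and a modest one. Nothing shown gives a reason for either step.

As far as these compounds go, it remains open how a carboxylic acid or an amine on this benzyl group, or a longer chain in its place, would compare. From the compounds shown here alone, it is also open whether the 4-chlorobenzyl group would carry the same step on the core of compound 1.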